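Swapping the halogen-bearing phenyl on the oxadiazole

A few compounds are considered here, and "the series" means these few. Any claim that something is new, unique, unknown or untested is made for them only; others in the source may bear on it.

Compound 1 `Cc1nc2cc(OC[C@H](O)CN3CCN(Cc4noc(-c5ccc(Cl)cc5)n4)CC3)ccc2s1`: 2270 nM
Compound 2 `Cc1nc2cc(OC[C@H](O)CN3CCN(Cc4nc(-c5ccc(C(C)(C)C)cc5)no4)CC3)ccc2s1`: 570 nM

In a functional assay on mitochondria from heart for inhibition of peroxisomal acyl-coenzyme A oxidase 1 (Rattus norvegicus) (on this read-out higher numbers stand for weaker inhibition and lower numbers for stronger inhibition), compound 1 gives 2270 nM, the highest of the two numbers; its nearest neighbour, compound 2, gives 570 nM, a gap beyond the scatter. Compound 3 `Cc1nc2cc(OC[C@H](O)CN3CCN(Cc4noc(-c5cccc(F)c5)n4)CC3)ccc2s1` differs from compound 1 in one place: 3-fluorophenyl in place of 4-chlorophenyl on an aromatic carbon. Within the data shown here, no pair differing only in this way has been measured, so the step of a 1.3-fold higher number from compound 1 to compound 3 (0.12 log units; within the scatter) is an expectation only, a small drift toward a higher number that may well stay within the scatter. For compound 3 the estimate is 3000 nM, within 1000 nM to 9000 nM.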

Compound 3, half-maximal inhibitory concentration: 13400 nM
Beside the measured number, compound 3's estimate is 4.5-fold (0.65 log units) below it, outside the stated range (above it).
By their numbers in this assay, from the lowest: compound 2; then compound 1; then compound 3.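

In this assay, 3-fluorophenyl in place of 4-chlorophenyl gives a 5.9-fold higher number from compound 1 to compound 3 (0.77 log units; beyond the scatter) and so shows that this position responds to a swap that leaves the heavy-atom count and the carbon-only aromatic ring unchanged. Since the halogen and its place on the phenyl change together, this single step cannot assign the shift to either one. Nothing measured here offers a reason for the shift. Which of the two changes carries the step stays open. Also open, from the compounds shown here alone, is what an unsubstituted phenyl or a methoxy-bearing phenyl would give on this carbon.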